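A few compounds are considered here, and "the series" means these few. Any claim that something is new, unique, unknown or untested is made for them only; others in the source may bear on it.

Working notes on the series. Compound 1 `CS(=O)(=O)CCCn1c(Cn2c(=O)n(C3CN(S(C)(=O)=O)C3)c3ccncc32)cc2cc(Cl)ccc21`, compound 2 `N#CCCCn1c(Cn2c(=O)n(-c3ccncc3F)c3ccncc32)cc2cc(Cl)ccc21` and compound 3 `CS(=O)(=O)CCCn1c(Cn2c(=O)n(CC3CC3)c3ccncc32)cc2cc(Cl)ccc21` share one core and have been tested in an ADME assay on HeLa cells (Homo sapiens) for cytotoxicity, read by ATP content, with a stated time of 3 days; on this read-out lower numbers stand for higher toxicity in this test and higher numbers for lower toxicity in this test. In this assay compound 1 gives > 50000 nM, which is a limit of the assay and not a number. In this assay compound 2 likewise gives only a limit, > 50000 nM. Compound 3 also gives only a limit in this assay, > 50000 nM. Compound 3 thus stands where every measured value of the set stands, namely (the limit of > 50000 nM in this assay, at which 3 of the 3 values shown sit). Within the data shown here, the single one-place step among the measured compounds, a step that the two limits leave unreadable from compound 1 to compound 3, cannot be read, since both ends are limits.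

Compound 4 `CS(=O)(=O)CCCn1c(Cn2c(=O)n(C3COC3)c3ccncc32)cc2cc(Cl)ccc21` has not yet been measured. It differs from compound 3 in one place: oxetan-3-yl in place of cyclopropylmethyl on an aromatic nitrogen. Among the measured compounds shown here, no measured step speaks to this exchange with a readable size, and the only step measured at the same aromatic nitrogen is unreadable. With every measured value of the set at the limit, compound 4 is expected to sit there as well, so the expected step that the limit leaves unreadable from compound 3 to compound 4 is none beyond the scatter. The estimate for compound 4 in this assay is 60000 nM, with a range from 30000 nM to 120000 nM, most likely reported again only as a limit.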

Compound 4, half-maximal cytotoxic concentration: > 50000 nM
Compound 4 ended at the assay's limit (the forecaster's own chance of this, stated with the estimate: 85%); the middle value does not contradict the limit.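

In this assay compound 4 gives > 50000 nM, a limit of the assay and not a number, so neither the step from compound 3 to compound 4 nor the step from compound 1 to compound 4 can be read. The compounds shown leave open whether any group on this aromatic nitrogen changes the read-out, as every value stands at one place: the limit of > 50000 nM in this assay, at which 4 of the 4 values shown sit.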